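The compounds below may be only part of what the source reports. "The series", "measured", "known", "first", "only" and "open" are said of these compounds alone.

Measured compounds: compound 1 `Cc1cn([C@@H]2O[C@H](CO[Si](C)(C)C(C)(C)C)[C@@]3(OS(=O)(=O)C=C3NC(=O)NC(=O)c3ccccc3)[C@H]2O[Si](C)(C)C(C)(C)C)c(=O)n(C)c1=O`, > 200000 nM; compound 2 `Cc1cn([C@@H]2O[C@H](CO[Si](C)(C)C(C)(C)C)[C@@]3(OS(=O)(=O)C=C3NC(=O)Nc3ccccc3)[C@H]2O[Si](C)(C)C(C)(C)C)c(=O)n(C)c1=O`, 1300 nM.

In an ADME assay on HEL cells (Homo sapiens) for cytotoxicity, with a stated time of 3 days (on this read-out higher numbers stand for lower toxicity in this test and lower numbers for higher toxicity in this test), compound 1 gives > 200000 nM, which is a limit of the assay rather than a number. In this assay compound 2 gives 1300 nM, the only number shown among the two compounds. For the measured compounds named here, the one measured step runs an at least 150-fold lower number from compound 1 to compound 2 (2.18 log units; beyond the scatter), and it rests on (the limit of > 200000 nM in this assay, at which 1 of the 2 values shown sits), so its true size is not known beyond that floor.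

Compound 3 `Cc1cn([C@@H]2O[C@H](CO[Si](C)(C)C(C)(C)C)[C@@]3(OS(=O)(=O)C=C3NC(=O)N(C(=O)Nc3ccccc3)c3ccccc3)[C@H]2O[Si](C)(C)C(C)(C)C)c(=O)n(C)c1=O` differs from compound 2 by phenylcarbamoyl in place of hydrogen on an amide-type nitrogen. This change again places a carbonyl-bearing group on the nitrogen that carries the phenyl, which is the kind of substitution that compound 1 carried when it sat at the limit. On that basis the step is expected to raise the number in this assay, probably by a large amount: the step from compound 2 to compound 3 is estimated as a 23-fold higher number from compound 2 to compound 3 (1.36 log units; beyond the scatter). For compound 3 the expected value in this assay is 30000 nM, within a range of 5000 nM to 200000 nM.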

Compound 3, half-maximal cytotoxic concentration: 13000 nM
Beside the measured number, compound 3's estimate is 2.3-fold (0.36 log units) above it, within the range that was stated.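

Phenylcarbamoyl in place of hydrogen on the amide-type nitrogen gives a 10-fold higher number from compound 2 to compound 3 (1.00 log units; beyond the scatter) in this assay. This shows that the number can move towards lower toxicity in this test through a change at this nitrogen, and here the size of the step can be read in full. The earlier step gave only a floor, since compound 1 stands at a limit of the assay rather than at a number: the limit of > 200000 nM in this assay, at which 1 of the 3 values shown sits.

The carbonyl and the added phenyl entered in one change, and the compounds shown do not separate them. They also leave open how the number would respond to a simple methyl or acetyl group on this nitrogen, or to a chain ending in an amine.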